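A side-chain swap on a short stability record

The source may report more compounds than this note shows. Statements on the series, on what has been measured and on what is new or still open speak of the compounds shown alone.

- Compound 1 `CCC(C)n1nc(-c2cccs2)c(O)c(C2=NS(=O)(=O)c3cc(NS(C)(=O)=O)ccc3N2)c1=O` shows > 1 h as a limit
- Compound 2 `CS(=O)(=O)Nc1ccc2c(c1)S(=O)(=O)N=C(c1c(O)c(-c3cccs3)nn(CC3(C(F)(F)F)CCC3)c1=O)N2` shows 1 h as a number

Among the measured compounds shown here, in an in vitro ADME assay on microsomes from liver (Homo sapiens) for metabolic stability, tested at 5 uM (a lower number here means that the compound disappears faster, a higher number that the compound lasts longer), compound 2 gives 1 h as the only true number so far. Compound 1 gives > 1 h and that is a limit, not a number.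

Compound 3 `CS(=O)(=O)Nc1ccc2c(c1)S(=O)(=O)N=C(c1c(O)c(-c3cccs3)nn(CCC3CCCC3)c1=O)N2` keeps the shared core and alters the side group on the ring nitrogen. The difference is cyclopentylmethyl in place of 1-(trifluoromethyl)cyclobutyl on a saturated chain carbon bound to an aromatic nitrogen and, in words, it puts cyclopentylmethyl in place of 1-(trifluoromethyl)cyclobutyl on a saturated chain carbon bound to an aromatic nitrogen.

For the measured compounds named here, only one measured step bears on this change. As far as these compounds go, that step a number no higher from compound 1 to compound 2 (the limit leaves the size open) altered the same side group, and its size stays open. It therefore hints at a direction at best and gives no size to carry over. The expected change a 1.3-fold lower number from compound 2 to compound 3 (0.10 log units; within the scatter) in this assay is an estimate that stays within the usual scatter and leans slightly lower. For compound 3 the estimated half-life is 0.8 h with an expected range from 0.35 h to 1.6 h for now.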

Compound 3, half-life: > 1 h
Compound 3 ended at the assay's limit; the forecaster's own chance of this, stated with the estimate: 30%; at least 1.2-fold (0.09 log units) between middle value and limit.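

In this assay compound 3 gives > 1 h, which is a limit of the assay and not a number. Putting cyclopentylmethyl in place of 1-(trifluoromethyl)cyclobutyl on a saturated chain carbon bound to an aromatic nitrogen gives a number no lower from compound 2 to compound 3 (the limit leaves the size open), so at this position a side chain with no fluorine and a five-membered ring did not bring the number down. The size of this step stays unknown and the step between the two limits, from compound 1 to compound 3, cannot be read, because most of this short record sits at one limit: the limit of > 1 h in this assay, at which 2 of the 3 values shown sit.

The compounds shown therefore leave open how long compound 1 and compound 3 really last, and whether either of them differs from compound 2 by more than the usual scatter of the measurement. They also leave open how the half-life responds when the side chain on the aromatic nitrogen carries something of another kind, such as an amine or a carboxylic acid, since all three side chains shown are built from carbon, with fluorine as the only addition.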